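The compounds below may be only part of what the source reports. "The series", "measured", "known", "first", "only" and "open" are said of these compounds alone.

Measured compounds:
compound 1, `CS(=O)(=O)N(COC(=O)c1ccccc1)c1ccc([N+](=O)[O-])cc1Oc1ccccc1`, half-life 0.0322 h
compound 2, `O=C(OCc1ccccc1)[C@H]1O[C@@H](Oc2cc3oc(-c4ccc(O)cc4)cc(=O)c3c(O)c2O)[C@H](O)[C@@H](O)[C@@H]1O`, half-life 1.47 h

Both compounds were tested in an ADME assay on a cell-free system (plasma, Homo sapiens) for metabolic stability; on this read-out higher numbers stand for a longer-lived compound and lower numbers for a shorter-lived compound. Compound 2 stands highest of the two numbers in this assay, and its nearest neighbour, compound 1, gives a far lower number; the gap between them lies well beyond the scatter. Compound 1 and compound 2 differ in many places at once, so their two values say nothing about any single structural change.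

Compound 3, `CCOC(=O)[C@H]1O[C@@H](Oc2cc3oc(-c4ccc(O)cc4)cc(=O)c3c(O)c2O)[C@H](O)[C@@H](O)[C@@H]1O`, has not yet been measured in this assay. It differs from compound 2 in one place: methyl in place of phenyl on a saturated chain carbon bound to an oxygen next to a carbonyl group. Within the data shown here, no pair of measured compounds isolates this change, so there is no measured step to lean on. With only this to go by, the step from compound 2 to compound 3 in this assay is expected to be small, close to the usual scatter, and if anything slightly upward, as a 1.4-fold higher number from compound 2 to compound 3 (0.13 log units; within the scatter). Compound 3 is therefore estimated at 2 h, with a range from 0.7 h to 6 h.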

Compound 3, half-life: 4.55 h
For compound 3 the middle estimate is 2.3-fold (0.36 log units) below the measured one; low and high end bracket the measured number.
By their numbers in this assay, from the lowest: compound 1; then compound 2; then compound 3.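

Replacing phenyl with methyl, on a saturated chain carbon bound to an oxygen next to a carbonyl group, gives a 3.1-fold higher number from compound 2 to compound 3 (0.49 log units; beyond the scatter) in this assay. Among these compounds, this is the first comparison here that isolates a single change, and it shows that this position is not neutral: even with the rest of the molecule unchanged, going from benzyloxycarbonyl to ethoxycarbonyl moves the half-life by more than repeat measurements would be expected to. Among the compounds shown here, the data show only that the compound with the ethoxycarbonyl group has the higher number, and no measurement at hand accounts for the rise.

As far as these compounds go, a single step gives a direction for one pair of groups, not a trend, so it remains open whether the number would keep changing in the same way across a series of groups at this place, such as a propyl or butyl chain in place of the ethyl, or with a free carboxylic acid or an amide in place of the ethoxycarbonyl group. From the compounds shown here alone, it is also open whether the same change would have a similar effect on a different core.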